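Ring swap on the sulfonamide of compound 2

The compounds below may be only part of what the source reports. "The series", "measured", "known", "first", "only" and "open" are said of these compounds alone.

Going by the values given here, in a physicochemical assay for lipophilicity (a higher number here means a more lipophilic compound, a lower number a more polar compound), compound 1 `Cc1nc(-c2cc(C(F)(F)F)ccc2[C@H]2CCOc3cc(S(=O)(=O)Nc4cccc(F)n4)ccc32)co1` gives 4 and compound 2 `Cn1nccc1-c1cc(C(F)(F)F)ccc1[C@H]1CCOc2cc(S(=O)(=O)Nc3cccc(F)n3)ccc21` gives 3.6 as the lower of the two numbers so far. Compound 3 `O=S(=O)(Nc1nccs1)c1ccc2c(c1)OCC[C@H]2c1ccc(C(F)(F)F)cc1-c1ccc(F)nc1` is recorded as "not determined" (no result reported) and offers no guide. The next change leads to compound 4 `Cn1nccc1-c1cc(C(F)(F)F)ccc1[C@H]1CCOc2cc(S(=O)(=O)Nc3ccncn3)ccc21` and reads pyrimidin-4-yl in place of 6-fluoropyridin-2-yl on a sulfonamide nitrogen on a sulfonamide nitrogen. Among the compounds with values here, the only measured step is a number 0.40 log units lower from compound 1 to compound 2 (beyond the scatter) on an aromatic carbon. Within the data shown here, no measured step involves the sulfonamide nitrogen, so this one gives only a rough scale. A fall somewhat larger than that is expected, estimated as a number 0.80 log units lower from compound 2 to compound 4 (beyond the scatter) in this assay for now. For compound 4 the estimate is 2.8 with an expected range of 2.2 to 3.4 at this stage.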

Compound 4, distribution coefficient: 1.8
Compound 4: middle estimate off by 1.00 log units, on the high side; the measured number lies below the stated range.
By their numbers in this assay, from the lowest: compound 4; then compound 2; then compound 1.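

In this assay, going by these compounds alone, the sulfonamide nitrogen proves far more responsive than the aromatic carbon changed earlier: pyrimidin-4-yl in place of 6-fluoropyridin-2-yl gives a number 1.80 log units lower from compound 2 to compound 4 (beyond the scatter) and the only earlier step is a number 0.40 log units lower from compound 1 to compound 2 (beyond the scatter). The change removes the fluorine and adds a second ring nitrogen together, and this single step cannot separate the two. No evidence on the cause of the shift is available.

Going by these compounds, whether plain pyridin-2-yl would fall nearer compound 2 or compound 4 remains open. Also open, on these data alone, is whether the same swap on compound 1 gives a step of similar size.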